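Replacing a Basic Ring on the Sulfonamide Nitrogen

The compounds below may be only part of what the source reports. "The series", "measured", "known", "first", "only" and "open" are said of these compounds alone.

Compound 3 `CN1CCC(NS(=O)(=O)c2ccccc2Nc2cc(-c3ccc4ccn(C)c4c3)c3nccnc3c2)C1` gives 3160 nM in an assay on lysate for inhibition of 6-phosphofructo-2-kinase/fructose-2,6-bisphosphatase 3 (Homo sapiens), with stated times of 0.5 min and 45 min (a higher number here means a weaker inhibitor, a lower number a stronger inhibitor), the lowest of the numbers shown. Compound 2 `CN1CCCC(NS(=O)(=O)c2ccccc2Nc2cc(-c3ccc4ccn(C)c4c3)c3nccnc3c2)C1` gives 9780 nM in this assay, so that a 3.1-fold lower number from compound 2 to compound 3 (0.49 log units; beyond the scatter). Compound 1 `CNS(=O)(=O)c1ccccc1Nc1cc(-c2ccc3ccn(C)c3c2)c2nccnc2c1` reaches only the limit > 100000 nM in this assay (the limit of > 100000 nM in this assay, at which 1 of the 3 values shown sits). Both larger steps come from putting a ring with a nitrogen in place of methyl on the sulfonamide nitrogen: an at least 10-fold lower number from compound 1 to compound 2 (1.00 log units; beyond the scatter) and an at least 31-fold lower number from compound 1 to compound 3 (1.50 log units; beyond the scatter). Compound 4 `CN(Cc1cncnc1)S(=O)(=O)c1ccccc1Nc1cc(-c2ccc3ccn(C)c3c2)c2nccnc2c1` is not yet measured; it differs from compound 3 in that (methyl((pyrimidin-5-yl)methyl)amino in place of (1-methylpyrrolidin-3-yl)amino on a sulfonyl sulfur). Compound 4 a 9.5-fold higher number from compound 3 to compound 4 (0.98 log units; beyond the scatter) is therefore expected to give a higher number, since the steps of an at least 10-fold lower number from compound 1 to compound 2 (1.00 log units; beyond the scatter) and an at least 31-fold lower number from compound 1 to compound 3 (1.50 log units; beyond the scatter) rewarded such a ring while compound 4 gives it up. The estimate for compound 4 is 30000 nM, with a range from 8000 nM to 120000 nM.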

Compound 4, half-maximal inhibitory concentration: > 100000 nM
Compound 4 gave a limit, no number; the forecaster's own chance of this, stated with the estimate: 30%; middle value at least 3.3-fold (0.52 log units) from the limit.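

Putting methyl((pyrimidin-5-yl)methyl)amino in place of the rings on the sulfonyl sulfur gives an at least 31-fold higher number from compound 3 to compound 4 (1.50 log units; beyond the scatter) and an at least 10-fold higher number from compound 2 to compound 4 (1.00 log units; beyond the scatter). So at this position, not every ring containing nitrogen retains what compounds 2 and 3 gained. Compound 4 stands at a limit, not a number, and the step from compound 1 to compound 4 cannot be read: the limit of > 100000 nM in this assay, at which 2 of the 4 values shown sit.

This change swaps the ring and also removes the sulfonamide hydrogen, so the two effects cannot be separated. On these data alone, it also remains open whether a 2-(dimethylamino)ethyl chain could replace the non-aromatic rings.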